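Replacing the methacryloyl arm with a chlorinated chain

This account rests on a few compounds, and the source may have more. Where it says the series, first, only, none or still open, it means among the compounds named here.

Of the compounds shown here, two have been measured in a functional assay on KYSE-450 cells (Homo sapiens) for inhibition, read by MTT assay, with a stated time of 48 h; a higher number here means a weaker inhibitor, a lower number a stronger inhibitor. Compound 2, `C=C(C)C(=O)N(Cc1ccc(OC)c(O)c1)c1cc(OC)c(OC)c(OC)c1`, gives 200 nM, the lowest of the two numbers. Within the data shown here, compound 1, `C/C=C/C(=O)N(Cc1ccc(OC)c(OC)c1)c1cc(OC)c(OC)c(OC)c1`, differs from it in more than one place and gives 39100 nM, a number far higher than that of compound 2 and well beyond the usual scatter; the two values show only that compound 2 is by far the stronger inhibitor of the pair.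

Compound 3, `COc1ccc(CN(C(=O)CCCCCl)c2cc(OC)c(OC)c(OC)c2)cc1O`, has not yet been measured. It is obtained from compound 2 by one change on the carbonyl carbon: 4-chlorobutyl in place of 1-methylethenyl on a carbonyl carbon. A saturated chain with a terminal chlorine now takes the place of the unsaturated branch. Among the measured compounds shown here, with no measured step of this kind available, the expectation is a clear loss of potency, a step of a 15-fold higher number from compound 2 to compound 3 (1.18 log units; beyond the scatter) in this assay. Compound 3 is therefore estimated at 3000 nM, within a range from 600 nM to 20000 nM.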

Compound 3, half-maximal inhibitory concentration: 770 nM
The estimate for compound 3 lay 3.9-fold (0.59 log units) above the measured number, and the stated range covers the measured number.
By their numbers in this assay, from the lowest: compound 2; then compound 3; then compound 1.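

Compound 3 shows that the carbonyl carbon can carry something quite different from 1-methylethenyl and still give a strong result. In this assay the change to 4-chlorobutyl gives a 3.9-fold higher number from compound 2 to compound 3 (0.59 log units; beyond the scatter). That is a real loss, but a modest one, so a double bond outside the aromatic rings is not essential at this place, and a longer saturated chain ending in chlorine is accepted here.

Open, going by these compounds, is whether the chlorine contributes at all, since a plain butyl chain would separate the effect of the chlorine from that of the chain itself. A shorter 3-chloropropyl chain or a 4-aminobutyl chain would show how much this place tolerates, and no measurement to hand explains the size of this step.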